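Replacing a thioether with an ether in a cytotoxicity series

A few compounds are considered here, and "the series" means these few. Any claim that something is new, unique, unknown or untested is made for them only; others in the source may bear on it.

Compound 2 `Nc1cc(N)c2nc(-c3ccccc3)c(Sc3ccc(Cl)c(Cl)c3)nc2c1` was tested in a functional assay on NCI-H226 cells (Homo sapiens) for inhibition, read by sulforhodamine B assay, with a stated time of 48 h; on this read-out higher numbers stand for lower toxicity in this test and lower numbers for higher toxicity in this test. In this assay compound 2 gives < 100000 nM, which is a limit of the assay rather than a measured number. Compound 1 `COc1ccc(Sc2nc3cc(N)cc(N)c3nc2-c2ccccc2)cc1` was tested in the same way; in this assay compound 1 gives < 100000 nM, again a limit. The change between the two, a step that the two limits leave unreadable from compound 1 to compound 2, therefore cannot be sized. the limit of < 100000 nM in this assay, at which 2 of the 2 values shown sit, sums up the picture: every value shown so far is such a limit.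

Compound 3 `Nc1cc(N)c2nc(-c3ccccc3)c(Oc3ccc(F)cc3)nc2c1` differs from compound 2 in one place: 4-fluorophenoxy in place of (3,4-dichlorophenyl)sulfanyl on an aromatic carbon. The new group sits on an aromatic carbon next to the ring nitrogen and ortho to a phenyl group. Going by the values given here, no measured step bears directly on this exchange, and the only step that exists, from compound 1 to compound 2, is unreadable. Nothing here supports a step beyond the scatter in either direction in this assay. Compound 3 is expected to give 20000 nM, within a range from 3000 nM to 100000 nM. The estimated step is a step that the limit leaves unreadable from compound 2 to compound 3, and the assay may well again report only a limit.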

Compound 3, concentration lethal to 50% of the cells: < 100000 nM
Compound 3 ended at the assay's limit (the forecaster's own chance of this, stated with the estimate: 70%); the middle value lies beyond the limit too.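

No step can be read between compound 1, compound 2 and compound 3, because each value is a limit of the assay and not a measured number: the limit of < 100000 nM in this assay, at which 3 of the 3 values shown sit. In this assay the compounds shown leave open how far either the change of group on the sulfur or the exchange of the sulfur link for an oxygen link shifts toxicity.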